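Anilino ring halogen swap in the enaminone series

A few compounds are considered here, and "the series" means these few. Any claim that something is new, unique, unknown or untested is made for them only; others in the source may bear on it.

Compound 1 `COc1ccc(-c2nc(C(=O)/C=C\Nc3ccc(Cl)cc3)c3ccccn23)cc1` gives 1240 nM in a functional assay on B16-F10 cells (Mus musculus) for cytotoxicity, read by MTT assay, with a stated time of 48 h (a lower number here means a stronger inhibitor, a higher number a weaker inhibitor), and stands lowest of the two numbers available, its nearest neighbour being compound 3. Compound 2 `O=C(/C=C\Nc1ccc(Cl)cc1)c1nc(-c2ccc(C(F)(F)F)cc2)n2ccccc12` returns only a limit of this assay, > 30000 nM, and so carries no number (the limit of > 30000 nM in this assay, at which 1 of the 3 values shown sits). Compound 3 `O=C(/C=C\Nc1ccc(Cl)cc1)c1nc(-c2ccc(F)cc2)n2ccccc12` gives 11000 nM in this assay. The measured steps all sit on the aryl ring attached to the shared core, not on the anilino ring: an at least 24-fold higher number from compound 1 to compound 2 (1.38 log units; beyond the scatter), an 8.9-fold higher number from compound 1 to compound 3 (0.95 log units; beyond the scatter) and an at least 2.7-fold lower number from compound 2 to compound 3 (0.43 log units; beyond the scatter). Both departures from methoxy on that ring weaken activity, the trifluoromethyl one more than the fluoro one.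

Compound 4 `COc1ccc(-c2nc(C(=O)/C=C\Nc3ccc(F)cc3)c3ccccn23)cc1` keeps the methoxy of compound 1 and alters the anilino ring instead: fluoro in place of chloro on an aromatic carbon. Going by the values given here, no measured step covers this position, so the expectation rests on the small size of the change and on the value of compound 1 in this assay. Compound 4 is expected near 1800 nM, within 700 nM to 5000 nM. The implied step a 1.5-fold higher number from compound 1 to compound 4 (0.16 log units; within the scatter) is expected to stay within the scatter, with any drift more likely toward a slightly higher number than a lower one.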

Compound 4, half-maximal inhibitory concentration: > 30000 nM
Compound 4 was reported as a limit; the forecaster's own chance of this, stated with the estimate: 3%; middle value at least 16-fold (1.22 log units) away from the limit.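

Until now every measured step lay on the aryl ring attached to the shared core. The anilino ring now proves just as sensitive: in this assay, fluoro in place of chloro, para to a large group, gives an at least 24-fold higher number from compound 1 to compound 4 (1.38 log units; beyond the scatter). With the methoxy held fixed, this one halogen swap changes no ring and no count of hydrogen-bond donors or acceptors, yet it separates a measurable compound from one without a number. Going by these compounds, compound 4 is reported only as a limit of the assay, so the true size of this step stays unknown: the limit of > 30000 nM in this assay, at which 2 of the 4 values shown sit.

Still open, on these data alone, is whether chloro is specifically favoured at this position or whether a bromo, a methyl or an amine on the anilino ring would also keep activity. Also open, as far as these compounds go, is whether the cost of the fluoro depends on the group on the other aryl ring, since the step rests on a single pair with methoxy there.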